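A Fluorine Added to Two Related Cores

A few compounds are considered here, and "the series" means these few. Any claim that something is new, unique, unknown or untested is made for them only; others in the source may bear on it.

Compound 1 `Oc1cccc2[nH]c(-c3ccc(-c4ccc(-c5ccccc5)cc4)cc3)nc12` and compound 2 `Oc1cccc2[nH]c(-c3ccc(-c4ccc(-c5ccc(F)cc5)cc4)cc3)nc12` share one core. In a functional assay on PC-3 cells (Homo sapiens) for inhibition, read by sulforhodamine B assay (on this read-out lower numbers stand for stronger inhibition of growth and higher numbers for weaker inhibition of growth), compound 1 gives 1240 nM, and compound 2 gives 15300 nM. The change between them is fluoro in place of hydrogen on an aromatic carbon, and it made a 12-fold higher number from compound 1 to compound 2 (1.09 log units; beyond the scatter). Compound 3 `Cc1ccc2[nH]c(-c3ccc(-c4ccc(-c5ccccc5)cc4)cc3)nc2c1` carries a different core; how the two cores differ is not broken down here. In this assay compound 3 gives 100000 nM, the highest of the three numbers. Compound 4 `Cc1ccc2[nH]c(-c3ccc(-c4ccc(-c5ccc(F)cc5)cc4)cc3)nc2c1` arises from compound 3 by the same change, (fluoro in place of hydrogen on an aromatic carbon), at the same place as before. Its result in this assay is not yet known, but an expectation can be drawn from what has been seen. For compound 4 the expected step is no change at the digits printed from compound 3 to compound 4 (within the scatter), because compound 1 moving to compound 2 showed a 12-fold higher number from compound 1 to compound 2 (1.09 log units; beyond the scatter). Little room remains above compound 3, because compound 3 already gives 100000 nM, the highest number among the measured compounds. Compound 4 is expected at 100000 nM, with a range from 40000 nM to 300000 nM.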

Compound 4, concentration for 50% growth inhibition: 100000 nM
For compound 4 middle estimate and measured number coincide at the digits printed; the measured number falls inside the stated range.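

Carried from the core of compound 1 to the core of compound 3, the change from phenyl to 4-fluorophenyl did not behave alike in this assay: the same change on two cores in this assay, a 12-fold higher number (1.09 log units; beyond the scatter) from compound 1 to compound 2 and no change at the digits printed (within the scatter) from compound 3 to compound 4, 12-fold (1.09 log units) apart, beyond the scatter of two such steps

On the second core there is no change at the digits printed from compound 3 to compound 4 (within the scatter), so the large weakening seen on the first core cannot be assumed to travel with the fluoro group to another core in this series. This comparison rests on a single pair for each core and does not show why the two cores part ways; compound 3 already has the highest number among the earlier compounds, and compound 4 gives 100000 nM, so this pair cannot tell how fluoro would act on a more strongly inhibiting compound with this core.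

Left open is what other groups in the same place would do on these two cores, such as a chlorine atom, a methoxy group or an amine. Also open, from the compounds shown here alone, is whether a carboxylic acid there would shift the numbers on both cores alike or, as with fluoro, on only one.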